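Compound 3 to compound 4 at the solubility limit

A few compounds are considered here, and "the series" means these few. Any claim that something is new, unique, unknown or untested is made for them only; others in the source may bear on it.

Three compounds share one core and differ on a carbonyl carbon: compound 1 `CN1CCC(C(=O)N2Cc3c(NC(=O)C4CC4)n[nH]c3C2(C)C)CC1`, compound 2 `CN1CCC(C(=O)N2Cc3c(NC(=O)C4CCC4)n[nH]c3C2(C)C)CC1` and compound 3 `CN1CCC(C(=O)N2Cc3c(NC(=O)c4ccc(Cl)cc4)n[nH]c3C2(C)C)CC1`. In a physicochemical assay for solubility, at pH 7 (on this read-out higher numbers stand for higher solubility and lower numbers for lower solubility), compound 1 gives > 225000 nM, which is a limit and not a number. Compound 2 gives > 225000 nM, again a limit. Compound 3 gives > 225000 nM, also a limit. Compound 3 therefore has no number of its own, and the set stands at the limit of > 225000 nM in this assay, at which 3 of the 3 values shown sit.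

The next step leads to compound 4 `CN1CCC(C(=O)N2Cc3c(NC(=O)Nc4cccc(F)c4)n[nH]c3C2(C)C)CC1`: (3-fluorophenyl)amino in place of 4-chlorophenyl on a carbonyl carbon. In words, (3-fluorophenyl)amino comes in place of 4-chlorophenyl on a carbonyl carbon.

For the measured compounds named here, three measured steps concern the same carbonyl carbon: a step that the two limits leave unreadable from compound 1 to compound 2, a step that the two limits leave unreadable from compound 1 to compound 3 and a step that the two limits leave unreadable from compound 2 to compound 3. None has a readable size, and none brings in a (3-fluorophenyl)amino group, so they offer no size to carry over. In this assay no step beyond the scatter is expected, and no firm direction can be assigned. The expected step is an at least 1.1-fold lower number from compound 3 to compound 4 (0.05 log units; that floor lies within the scatter), and it is only loosely defined. For compound 4 the estimated solubility is 200000 nM, with an expected range of 70000 nM to 320000 nM. Another limit rather than a number is also a likely outcome.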

Compound 4, solubility: > 225000 nM
Compound 4: a limit, no number; the forecaster's own chance of this, stated with the estimate: 55%; at least 1.1-fold (0.05 log units) between middle value and limit.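

In this assay compound 4 gives > 225000 nM, which is a limit and not a number. The steps joining compound 4 to compound 1, compound 2 and compound 3 cannot be read, and the set stands at: the limit of > 225000 nM in this assay, at which 4 of the 4 values shown sit. The compounds shown leave open how the four would rank in solubility, and whether the group on the carbonyl carbon matters.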